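The source may report more compounds than this note shows. Statements on the series, on what has been measured and on what is new or still open speak of the compounds shown alone.

Measured compounds in a functional assay on brain for inhibition of Norepinephrine transporter (Rattus norvegicus); on this read-out lower numbers stand for stronger inhibition and higher numbers for weaker inhibition:

compound 1 `CN(C)C/C=C(/c1ccccc1)c1cccnc1`: 27000 nM
compound 2 `CCNC/C=C(/c1ccc(Br)cc1)c1cccnc1`: 26000 nM
compound 3 `CCCNC/C=C(/c1ccc(Br)cc1)c1cccnc1`: > 24000 nM

For compound 3 the read-out is a limit of this assay, > 24000 nM, not a number. Compound 1 and compound 2 sit within the scatter of each other; compound 1 gives the highest of the two numbers, by a gap that is within the scatter. Among the measured compounds shown here, the one step between neighbours, a step that the limit leaves unreadable from compound 2 to compound 3, is left unreadable by that limit (the limit of > 24000 nM in this assay, at which 1 of the 3 values shown sits).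

Compound 4 `CN(C)C/C=C(/c1ccc(I)cc1)c1cccnc1` differs from compound 1 by iodo in place of hydrogen on an aromatic carbon. For the measured compounds named here, no measured step concerns this position: compound 2 carries a bromo at the same place but also a different amine, and its value and that of compound 1 are within the scatter of each other. The unreadable step from compound 2 to compound 3 does not bear on the change.

With nothing measured on this change, the expected step of a 1.1-fold lower number from compound 1 to compound 4 (0.03 log units; within the scatter) is none beyond the scatter. Compound 4 is expected near 25000 nM, estimated within 8000 nM to 70000 nM, with a fair chance that this assay again reports only a limit.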

Compound 4, half-maximal inhibitory concentration: > 22000 nM
Compound 4: only a limit was reported (the forecaster's own chance of this, stated with the estimate: 35%); the middle value lies beyond the limit too.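

The iodo change cannot be read as a step from compound 1 to compound 4, because compound 4 is reported only as a limit: the limit of > 22000 nM in this assay, at which 1 of the 4 values shown sits.

The compounds shown leave open whether iodo in place of hydrogen on an aromatic carbon shifts the read-out in this assay at all.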